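A few compounds are considered here, and "the series" means these few. Any claim that something is new, unique, unknown or untested is made for them only; others in the source may bear on it.

The measurements all come from a functional assay on SW-620 cells (Homo sapiens) for antiproliferative activity, read by MTT assay, with a stated time of 72 h; on this read-out higher numbers stand for weaker inhibition and lower numbers for stronger inhibition. Compound 1, with the structure `COc1nc(CC(O)(COCc2ccccc2)COCc2ccccc2)c(C)c(OC)n1`, gives 3500 nM in this assay. Compound 2, `COCn1c(CC(O)(COCc2ccccc2)COCc2ccccc2)cc(=O)[nH]c1=O`, is built on a different core; in this assay compound 2 reaches only the limit of the method, > 100000 nM. Compound 3, `COCn1c(CC(O)(CO)CO)cc(=O)[nH]c1=O`, shares that second core in a smaller form. Compound 3 likewise sits at the limit of this assay, > 100000 nM, so no actual number is known for it; it stands at the limit of > 100000 nM in this assay, at which 2 of the 3 values shown sit.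

Compound 4, `C[Si](C)(C)CCOCn1c(CC(O)(CO)CO)cc(=O)[nH]c1=O`, differs from compound 3 in one place: a group of 5 heavy atoms (4 carbon, 1 silicon; no ring) in place of a hydrogen atom, on a saturated chain carbon bound to an oxygen on a saturated carbon. Among the compounds with values here, no step between two measured compounds is available, so any expectation can rest only on where compound 3 and compound 2 stand. Within the data shown here, both compounds with this core gave only a limit, and nothing among the measured compounds shows that a change of this kind moves the value in either direction. The expected step is therefore none beyond the scatter: in this assay the expectation means a step of a number no higher from compound 3 to compound 4 (the limit leaves the size open). Compound 4 is accordingly estimated at 100000 nM, with a range from 30000 nM to 300000 nM, and most likely this assay will once more report only a limit for it.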

Compound 4, half-maximal inhibitory concentration: > 100000 nM
Compound 4: a limit, no number; the forecaster's own chance of this, stated with the estimate: 80%; the middle value lies on the limit itself.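

Compound 3 and compound 4 both give only a limit and not a number, so no step can be read from one to the other: the limit of > 100000 nM in this assay, at which 3 of the 4 values shown sit.

The compounds shown leave open whether the group of 5 heavy atoms in place of a hydrogen atom changes the activity at all, in either direction.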